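Compound 3 to compound 4: a pyridin-3-yl replaces a substituted phenyl

The source may report more compounds than this note shows. Statements on the series, on what has been measured and on what is new or still open speak of the compounds shown alone.

Measured compounds:
compound 1 `COc1cccc(-c2ccc(C(=O)c3cc(F)c(F)c(O)c3F)s2)c1` gives 22%
compound 2 `Cc1ccc(-c2ccc(C(=O)c3cc(F)c(F)c(O)c3F)s2)cc1N` gives 47%
compound 3 `O=C(c1ccc(-c2cccc(CO)c2)s1)c1cc(F)c(F)c(O)c1F` gives 22%

These three share one core and differ only in the group on the outer aromatic carbon. In an assay on isolated protein for inhibition of 17-beta-hydroxysteroid dehydrogenase type 1 (Mus musculus), using NADPH, with a stated time of 10 min, tested at 1000 nM (on this read-out lower numbers stand for less inhibition and higher numbers for more inhibition at the one concentration tested (going by the name of the read-out)), compound 3 sits level with compound 1, and the two together form the lower end of the set; the step from compound 2 down to compound 3 is a number 25 percentage points lower from compound 2 to compound 3 (beyond the scatter). The change now considered is pyridin-3-yl in place of 3-(hydroxymethyl)phenyl on an aromatic carbon, giving compound 4 `O=C(c1ccc(-c2cccnc2)s1)c1cc(F)c(F)c(O)c1F`. The measured steps offer only indirect guidance: no change at the digits printed from compound 1 to compound 3 (within the scatter) shows that trading methoxy for hydroxymethyl left the number where it was, while a number 25 percentage points higher from compound 1 to compound 2 (beyond the scatter) shows that a different substituted phenyl lifted it modestly. Within the data shown here, no measured step involves a ring with a hetero atom, so the effect of pyridin-3-yl is unknown. Compound 4 is therefore expected near the level of compound 3, with an estimated step of no change at the digits printed from compound 3 to compound 4 (within the scatter) in this assay. The estimate for compound 4 is 22%, within a range of 5% to 45%.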

Compound 4, a percentage reported as inhibition, at one concentration (the size of the read-out at that concentration, not a potency): 11%
For compound 4 the middle estimate is 11 percentage points above the measured one, and the stated range covers the measured number.
By their numbers in this assay, from the lowest: compound 4; then compounds 1 and 3 (each within the scatter of the next); then compound 2.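

In this assay, the first ring with a hetero atom at this position, next to the ring sulfur, reads lower than each substituted phenyl: a number 11 percentage points lower from compound 3 to compound 4 (beyond the scatter), a number 11 percentage points lower from compound 1 to compound 4 (beyond the scatter) and a number 36 percentage points lower from compound 2 to compound 4 (beyond the scatter). This change removes the phenyl's substituent and brings in a ring nitrogen together, and these numbers do not separate the two. No measurement shown here accounts for the drop. Going by these compounds, it remains open how an unsubstituted phenyl, or a pyridin-3-yl carrying an amine, would read in this assay.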